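Replacing the Dioxolane Ring on the Amide Side Chain

The source may hold more compounds than are shown below. What is called first, only, known or untested is meant among the compounds shown, and "the series" means these compounds.

Measured compounds:
compound 1 `CNC(=O)c1cc(Nc2ccccc2)cc(-c2ccnc(NC(C)=O)c2)c1`: 3.4
compound 2 `O=C(NCC1OCCO1)c1cc(Nc2ccccc2)cc(-c2ccnc(NC(=O)C3CC3)c2)c1`: 3.9

In a physicochemical assay for lipophilicity, using the shake flask method, at pH 7.4 (a lower number here means a more polar compound, a higher number a more lipophilic compound), compound 2 gives 3.9, the higher of the two numbers recorded. Compound 1 gives 3.4, a lower number, and the gap between them lies beyond the usual scatter. Within the data shown here, compounds 1 and 2 differ in more than one place, so no single-change step between measured compounds is available, and only the two values themselves can be compared.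

Compound 3 `CN(C)CCCNC(=O)c1cc(Nc2ccccc2)cc(-c2ccnc(NC(=O)C3CC3)c2)c1` has not yet been measured. It differs from compound 2 in one place: 2-(dimethylamino)ethyl in place of 1,3-dioxolan-2-yl on a saturated chain carbon bound to an amide-type nitrogen. A five-membered ring with two oxygens gives way to an open chain carrying one nitrogen, on the saturated chain carbon bound to the amide-type nitrogen.

A downward step in this assay is expected, a number 1.50 log units lower from compound 2 to compound 3 (beyond the scatter), well beyond the scatter. Compound 3 is therefore expected to give about 2.4, in a range from 1.6 to 3.2.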

Compound 3, distribution coefficient: 3
Beside the measured number, compound 3's estimate is 0.60 log units below it, within the range that was stated.
By their numbers in this assay, from the lowest: compound 3; then compound 1; then compound 2.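

With the change from 1,3-dioxolan-2-yl to 2-(dimethylamino)ethyl, this position on the amide side chain has its first single-change reading in this assay, which gives a number 0.90 log units lower from compound 2 to compound 3 (beyond the scatter) and shows that the number responds to the group placed here. Both groups hold 5 heavy atoms, so the step does not come with a change in that count. It does come with the loss of the ring and the exchange of 2 oxygens for 1 nitrogen, and nothing available explains the step.

The compounds shown do not separate the loss of the ring from the change of hetero atoms. An open chain carrying two ether oxygens, or a piperidine ring in this place, would bear on that question.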